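The compounds below may be only part of what the source reports. "The series", "measured", "known", "first", "only" and "open" are said of these compounds alone.

- Compound 1, `C=C[C@@](C)(/C=C/c1ccc(Nc2ccc(Cl)c(F)c2)cc1)CCC=C(C)C`: > 43400 nM (a limit)
- Compound 2, `C=C[C@@](C)(/C=C/c1ccc(Nc2c(F)cc(F)cc2F)cc1)CCC=C(C)C`: > 43400 nM (a limit)

In a functional assay on NALM-6 cells (Homo sapiens) for cytotoxicity, with a stated time of 72 h (on this read-out lower numbers stand for an effect already at smaller amounts and higher numbers for an effect only at larger amounts of compound), compound 2 stands at > 43400 nM, a limit and not a number. Compound 1 also gives a limit, > 43400 nM. Among the measured compounds shown here, the only measured step is therefore a step that the two limits leave unreadable from compound 1 to compound 2. The whole record so far comes down to the limit of > 43400 nM in this assay, at which 2 of the 2 values shown sit.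

Compound 3, `C=C[C@@](C)(/C=C/c1ccc(Nc2ccc(Cl)c(Cl)c2)cc1)CCC=C(C)C`, is not yet measured. It keeps the shared core and changes one group, with 3,4-dichlorophenyl in place of 2,4,6-trifluorophenyl on a nitrogen on an aromatic ring.

For the measured compounds named here, the one earlier change of this group gave no step of readable size, so there is no measured size to carry over. Neither compound offers a reason to expect a clear shift in this assay, in either direction. The expected change is an at least 1.0-fold lower number from compound 2 to compound 3 (0.03 log units; that floor lies within the scatter), which amounts to no real move beyond the scatter, and a further limit is quite likely. The estimate for compound 3 is 40000 nM, with an expected range from 15000 nM to 60000 nM.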

Compound 3, half-maximal effective concentration: > 43400 nM
Compound 3: a limit, no number; the forecaster's own chance of this, stated with the estimate: 65%; middle value at least 1.0-fold (0.03 log units) from the limit.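

Compound 3 gives only a limit in this assay, as do compound 1 and compound 2, so the steps among these three compounds cannot be read: the limit of > 43400 nM in this assay, at which 3 of the 3 values shown sit. The compounds shown leave open whether any other group on the nitrogen would give a real number in this assay, rather than another limit.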